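A few compounds are considered here, and "the series" means these few. Any claim that something is new, unique, unknown or untested is made for them only; others in the source may bear on it.

Compound 1 `FC(F)(F)c1cccc(-c2nc3cnc(Nc4ccccn4)cc3[nH]2)c1` in a physicochemical assay for solubility, using the shake flask method, in phosphate buffer, measured as kinetic solubility, with a stated time of 20 h, at pH 6.5 (on this read-out higher numbers stand for higher solubility and lower numbers for lower solubility), gives < 5000 nM, which is a limit of the assay rather than a number. Compound 2 `Fc1cnc(Nc2cc3[nH]c(-c4cccc(C(F)(F)F)c4)nc3cn2)c(F)c1` gives < 5000 nM, likewise a limit. Compound 3 `O=C(O)c1ccnc(Nc2cc3[nH]c(-c4cccc(C(F)(F)F)c4)nc3cn2)c1` gives < 5000 nM, also a limit. The steps a step that the two limits leave unreadable from compound 1 to compound 2, a step that the two limits leave unreadable from compound 1 to compound 3 and a step that the two limits leave unreadable from compound 2 to compound 3 therefore carry no readable size, because of the limit of < 5000 nM in this assay, at which 3 of the 3 values shown sit. Compound 4 `NC(=O)c1ccc(Nc2cc3[nH]c(-c4cccc(C(F)(F)F)c4)nc3cn2)nc1` differs from compound 1 by carbamoyl in place of hydrogen on an aromatic carbon. Going by the values given here, none of the measured steps bears readably on this change, so no direction can be drawn from them; the series so far gives only limits. Compound 4 is expected to remain near the same limit, with a step that the limit leaves unreadable from compound 1 to compound 4 estimated as no readable step. The estimate for compound 4 is 3000 nM, within 500 nM to 15000 nM.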

Compound 4, solubility: < 5000 nM
Compound 4: only a limit was reported; the forecaster's own chance of this, stated with the estimate: 70%; the middle value is on the limit's open side.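

Compound 4, like compound 1, compound 2 and compound 3, gives only a limit, so no step among these compounds can be read: the limit of < 5000 nM in this assay, at which 4 of the 4 values shown sit.

As far as these compounds go, how far these four compounds actually lie apart in this assay remains open.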